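Methyl on the Phenyl Ring of Compound 4: An Expectation

The source may report more compounds than this note shows. Statements on the series, on what has been measured and on what is new or still open speak of the compounds shown alone.

Measured so far:
compound 1 `COc1cc2c(Oc3ccc(NC(=O)c4cc(-c5ccccc5)ccn4)cc3F)ccnc2cc1OCCCN1CCCC1`: 210 nM
compound 2 `COc1cc2c(Oc3ccc(NC(=O)c4cc(-c5ccccc5C)ccn4)cc3F)ccnc2cc1OCCCN1CCCC1`: 440 nM
compound 3 `COc1cc2c(Oc3ccc(NC(=O)c4nccc(-c5ccccc5)n4)cc3F)ccnc2cc1OCCCN1CCCC1`: 1360 nM

All three were tested in a functional assay on MKN-45 cells (Homo sapiens) for cytotoxicity, read by MTT assay, with a stated time of 72 h; on this read-out higher numbers stand for weaker inhibition and lower numbers for stronger inhibition. Compound 3 differs from compound 1 by 4-phenylpyrimidin-2-yl in place of 4-phenylpyridin-2-yl on a carbonyl carbon, and this change gave a 6.5-fold higher number from compound 1 to compound 3 (0.81 log units; beyond the scatter), leaving compound 3 with the highest number of the three. Compound 2 differs from compound 1 by methyl in place of hydrogen on an aromatic carbon, a change that gave a 2.1-fold higher number from compound 1 to compound 2 (0.32 log units; beyond the scatter).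

Compound 4 `COc1cc2c(Oc3ccc(NC(=O)c4nccc(-c5ccc(C)cc5)n4)cc3F)ccnc2cc1OCCCN1CCCC1` has not yet been measured in this assay. It differs from compound 3 by methyl in place of hydrogen on an aromatic carbon. This is the same kind of change as that from compound 1 to compound 2, but not the same: in compound 2 the methyl sits ortho to a large group, whereas in compound 4 it sits para to a large group. Going by the values given here, the only guide to its size is the earlier methyl step, which gave a 2.1-fold higher number from compound 1 to compound 2 (0.32 log units; beyond the scatter). On that basis compound 4 is expected to show a 1.6-fold higher number from compound 3 to compound 4 (0.21 log units; within the scatter), a step of roughly the same modest size. Compound 4 is therefore estimated at 2200 nM, with a likely range from 900 nM to 5500 nM.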

Compound 4, half-maximal inhibitory concentration: 240 nM
Estimate against measurement, compound 4: 9.2-fold (0.96 log units) above; measured number below the stated range.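

In this assay the change from phenyl to 4-methylphenyl gave a 5.7-fold lower number from compound 3 to compound 4 (0.75 log units; beyond the scatter), so the methyl step did not carry over from one core to the other in either size or direction: the same change on two cores in this assay, a 2.1-fold higher number (0.32 log units; beyond the scatter) from compound 1 to compound 2 and a 5.7-fold lower number (0.75 log units; beyond the scatter) from compound 3 to compound 4, 12-fold (1.07 log units) apart, beyond the scatter of two such steps. This shows that, in this series, the effect of a methyl on the phenyl ring cannot simply be transferred from one core to another. It does not show what lies behind the gap: the two steps differ in the core and also in where the methyl sits on the phenyl ring, and a single pair for each cannot separate the two, nor can it support a general rule for either core.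

The compounds shown leave open whether a methyl para to a large group on the core of compound 1 would also lower the number, which would separate place from core. They also leave open whether an ethyl group, a methoxy group or an amine in that place would follow the methyl.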